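This account rests on a few compounds, and the source may have more. Where it says the series, first, only, none or still open, it means among the compounds named here.

In a functional assay on MCF7 cells (Homo sapiens) for antiproliferative activity, read by MTT assay, with a stated time of 48 h (on this read-out lower numbers stand for stronger inhibition and higher numbers for weaker inhibition), compound 1 (`C=CCN(C)C(=O)c1ccc(C(CC)(CC)c2ccc(OCCC(O)(CC)CC)c(C)c2)n1CC`) gives > 50000 nM as a limit of the assay. Compound 2 (`CCn1c(C(=O)Nc2ccc(OC(F)(F)F)cc2)ccc1C(CC)(CC)c1ccc(OCCC(O)(CC)CC)c(C)c1`) gives > 50000 nM and this too is a limit, so compound 2 offers no number to start from. Compound 3 (`CCn1c(C(=O)NC(CC(=O)O)C(=O)OC)ccc1C(CC)(CC)c1ccc(OCCC(O)(CC)CC)c(C)c1`) carries this change: a group of 9 heavy atoms (5 carbon, 4 oxygen; no ring) in place of a group of 11 heavy atoms (7 carbon, 1 oxygen, 3 fluorine; one six-membered aromatic ring of carbon only), on an amide-type nitrogen at the same amide. Going by the values given here, the only measured step on this amide is a step that the two limits leave unreadable from compound 1 to compound 2 and it gives no size. Among the compounds with values here, the series so far shows only the limit of > 50000 nM in this assay, at which 2 of the 2 values shown sit, and no direction can be drawn from that. Expected here is a number no higher from compound 2 to compound 3 (the limit leaves the size open) with nothing foreseen beyond the scatter. For compound 3 the estimate is 50000 nM with an expected range from 20000 nM to 100000 nM in this assay.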

Compound 3, half-maximal inhibitory concentration: 10200 nM
Estimate against measurement, compound 3: 4.9-fold (0.69 log units) above, outside the stated range (below it).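

In this assay, the group of 9 heavy atoms, with no ring, on the amide-type nitrogen gives an at least 4.9-fold lower number from compound 2 to compound 3 (0.69 log units; beyond the scatter). Measured from the allyl(methyl)amino amide, the same group gives an at least 4.9-fold lower number from compound 1 to compound 3 (0.69 log units; beyond the scatter). Compound 3 is thus the first compound here to give a number rather than a limit: the limit of > 50000 nM in this assay, at which 2 of the 3 values shown sit.

Neither step has a fixed upper size, since compound 1 and compound 2 stand only as limits. Going by these compounds, it remains open whether a simple amine or a longer chain carrying a hydroxyl group on this nitrogen would also give a number.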